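The compounds below may be only part of what the source reports. "The series", "measured", "known", "first", "only" and "open" are said of these compounds alone.

Working notes on the series. In a toxicity assay on NIH3T3 cells (Mus musculus) for cytotoxicity, read by resazurin assay (a lower number here means that less compound is needed, a higher number that more compound is needed for the effect), compound 3 `COC(=O)c1ccc(NCc2cncn2Cc2ccccc2N)cc1-c1ccccc1` gives 25000 nM, the highest of the two numbers in hand; compound 2 `COC(=O)c1ccc(NCc2cncn2Cc2ccccc2Cl)cc1-c1ccccc1` gives 10000 nM, and for compound 1 `COC(=O)c1ccc(NCc2cncn2Cc2ccccc2C(C)(C)C)cc1-c1ccccc1` the entry reads "not determined" (no result reported), so no result is reported. Among the measured compounds shown here, the only step on record, a 2.5-fold higher number from compound 2 to compound 3 (0.40 log units; beyond the scatter), concerns a different substituent change and bears only loosely on the one now at hand. Compound 4 `COC(=O)c1ccc(NCc2cncn2Cc2ccc(C#N)cc2)cc1-c1ccccc1` differs from compound 3 by 4-cyanophenyl in place of 2-aminophenyl on a saturated chain carbon bound to an aromatic nitrogen. For the measured compounds named here, no measured step covers this exchange, so the expectation rests on the narrow spread of the two numbers seen. The step from compound 3 to compound 4 is expected to be a 1.7-fold lower number from compound 3 to compound 4 (0.22 log units; within the scatter), a small move toward compound 2. Compound 4 is therefore estimated at 15000 nM, with a range from 6000 nM to 40000 nM.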

Compound 4, half-maximal effective concentration: > 10000 nM
Compound 4: a limit, no number; the forecaster's own chance of this, stated with the estimate: 20%; the middle value lies beyond the limit too.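

In this assay compound 4 gives > 10000 nM, which is a limit and not a number. With 4-cyanophenyl in place of 2-chlorophenyl on the saturated chain carbon, the record shows a number no lower from compound 2 to compound 4 (the limit leaves the size open), so this exchange does not bring the number down, something the earlier pair could not show. The size of this step and of the step from compound 3 cannot be read: the limit of > 10000 nM in this assay, at which 1 of the 4 values shown sits.

From the compounds shown here alone, whether 4-cyanophenyl and 2-aminophenyl differ in this assay stays open. Also open, going by these compounds, is what a carboxylic acid in place of the nitrile on this ring would give.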